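The source may report more compounds than this note shows. Statements on the series, on what has been measured and on what is new or still open speak of the compounds shown alone.

Cytotoxicity has been measured for three related compounds in a functional assay on Raji cells (Homo sapiens) for cytotoxicity, with a stated time of 72 h; a higher number here means that more compound is needed for the effect, a lower number that less compound is needed. Compound 1 `C=C[C@@](C)(/C=C/c1ccc(O)cc1)CCC=O` gives > 26000 nM in this test, which is a limit of the assay and not a number. Compound 2 `C=C[C@@](C)(/C=C/c1ccc(O)c(C=O)c1)CCC=C(C)C` gives > 26000 nM in the same test, and this too is a limit of the assay. For the measured compounds named here, compound 3 `COc1ccc(/C=C/[C@@](C)(/C=C/c2ccc(O)c(C=O)c2)CCC=C(C)C)cc1` gives 13000 nM as the only true number in the set, so it stands alone as a measured point, and the other two results mark only where the assay stops reporting numbers.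

Compound 4 `COc1ccc(/C=C/[C@@](C)(/C=C/c2ccc(O)c(/C=C/C(C)=O)c2)CCC=C(C)C)cc1` keeps the core of compound 3 and changes one group. It carries 2-acetylethenyl in place of formyl on an aromatic carbon, ortho to a hydroxy group and meta to a large group: 2-acetylethenyl in place of formyl on an aromatic carbon.

Going by the values given here, no pair of measured compounds shows what a change of this kind does, so the guide here is thin. With compound 3 at 13000 nM as the only anchor, a small move in this assay toward less compound needed is expected, one that stays within the usual scatter. The estimated change is a 1.4-fold lower number from compound 3 to compound 4 (0.16 log units; within the scatter) on this reasoning. Compound 4 is expected at about 9000 nM with an estimated range from 3000 nM to 26000 nM in this test.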

Compound 4, half-maximal effective concentration: > 26000 nM
Compound 4: a limit, no number; the forecaster's own chance of this, stated with the estimate: 25%; middle value at least 2.8-fold (0.46 log units) away from the limit.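

In this assay, for the compounds shown here, the replacement of formyl by 2-acetylethenyl on this aromatic carbon, ortho to a hydroxy group, gives the first direct comparison at this position, and it reads as an at least 2.0-fold higher number from compound 3 to compound 4 (0.30 log units; that floor lies within the scatter). Compound 4 gives > 26000 nM, which is a limit of the assay and not a number. The longer group therefore does not keep the compound within the range where this test reports a number, but the lowest possible size of the step does not exceed the usual scatter, and its true size cannot be read because the reporting stops at a limit: the limit of > 26000 nM in this assay, at which 3 of the 4 values shown sit.

The compounds shown leave open whether any change at this position can lower the number in this assay, as a single replacement of formyl says little about the position as a whole. An amine, a carboxylic acid or a plain saturated carbon chain in place of formyl could separate the effect of the carbonyl from that of the added length, and these groups lie outside the compounds shown.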